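1H-pyrrol-2-yl on the chain carbon of compound 1

The compounds below may be only part of what the source reports. "The series", "measured", "known", "first", "only" and "open" are said of these compounds alone.

In a functional assay on DU-145 cells (Homo sapiens) for inhibition, read by trypan blue exclusion, with a stated time of 96 h (a lower number here means a stronger inhibitor of growth, a higher number a weaker inhibitor of growth), compound 1 (`Cc1ccc(S/C(=C/c2ccc(N(C)C)cc2)C(=O)c2ccc(Cl)cc2)cc1`) gives > 100000 nM as a limit and not a number. Compound 3 (`CN(C)c1ccc(/C=C(/SCc2ccccc2Cl)C(=O)c2ccc(Cl)cc2)cc1`) gives > 100000 nM as a limit too. Compound 1 therefore stands at the limit of > 100000 nM in this assay, at which 2 of the 3 values shown sit, and has no readable value. Compound 2 (`COc1cc(/C=C(/Sc2ccc(Br)cc2)C(=O)c2ccc(Br)cc2)ccc1F`) reads 10000 nM as a true number, but it differs from compound 1 in several places. The change to compound 4 (`Cc1ccc(S/C(=C/c2ccc[nH]2)C(=O)c2ccc(Cl)cc2)cc1`) reads 1H-pyrrol-2-yl in place of 4-(dimethylamino)phenyl on a double-bonded chain carbon bound to a double-bonded chain carbon and leaves the rest of the core of compound 1 untouched. Within the data shown here, the only measured step (a step that the two limits leave unreadable from compound 1 to compound 3) sits on a sulfur and has no readable size, so it sets no size for this change. Compound 2 at 10000 nM is the sole reason to expect a number at all. The expected step of an at least 2.5-fold lower number from compound 1 to compound 4 (0.39 log units; beyond the scatter) is a rough estimate, toward stronger inhibition of growth, and a result at the limit remains quite possible. The estimated value for compound 4 is 40000 nM in this assay with an expected range from 8000 nM to 100000 nM as its ends.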

Compound 4, concentration for 50% growth inhibition: 10000 nM
Compound 4: the middle estimate sits 4.0-fold (0.60 log units) above what was measured; the range from low to high includes it.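

In this assay, among these compounds, 1H-pyrrol-2-yl in place of 4-(dimethylamino)phenyl gives an at least 10-fold lower number from compound 1 to compound 4 (1.00 log units; beyond the scatter), the first readable step. Among the compounds shown here, the place on a double-bonded chain carbon bound to a double-bonded chain carbon therefore responds to change, whereas the one change on the sulfur has no readable size. The step is only a minimum, since compound 1 carries a limit and not a number: the limit of > 100000 nM in this assay, at which 2 of the 4 values shown sit.

The change swaps the ring, removes the dimethylamino group and brings in a hydrogen-bond donor all at once, and the compounds shown do not separate these. Also open, going by these compounds, is how an unsubstituted phenyl or a 1-methyl-1H-pyrrol-2-yl group in the same place would read, which would bear on that question.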